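Removing a Chloro Group from an Aryloxypropyl Triazine Core

The compounds below may be only part of what the source reports. "The series", "measured", "known", "first", "only" and "open" are said of these compounds alone.

Of the compounds shown here, two built on a shared triazine-containing spirocyclic core have been measured in a functional assay on HL-60 cells (Homo sapiens) for antiproliferative activity, read by MTT assay, with a stated time of 72 h; a higher number here means a weaker inhibitor, a lower number a stronger inhibitor. Compound 1, `NC1=NC2(CCOCC2)N(OCCCOc2ccccc2Cl)C(N)=N1`, gives 660 nM in this assay. Compound 2, `COc1ccc(OCCCON2C(N)=NC(N)=NC23CCSCC3)cc1`, carries a methoxy group on its phenoxy ring and a sulfur in place of the oxygen of the spiro ring; in this assay compound 2 gives 500 nM. The two values lie within the usual scatter of one another, so neither compound can be called the stronger inhibitor on these numbers alone.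

The step that follows goes from compound 1 to compound 3, `NC1=NC2(CCOCC2)N(OCCCOc2ccccc2)C(N)=N1`, which differs from compound 1 by a single atom: hydrogen in place of chloro on an aromatic carbon. Within the data shown here, no step between measured compounds of this kind is available, so the size of the effect is open. Among the measured compounds shown here, with only two measured values to go on, a small loss or no change beyond the scatter is expected, and compound 3 is estimated at 900 nM, within a range from 400 nM to 2000 nM. This estimate corresponds to an expected step of a 1.4-fold higher number from compound 1 to compound 3 (0.13 log units; within the scatter).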

Compound 3, half-maximal inhibitory concentration: 2460 nM
Estimate against measurement, compound 3: 2.7-fold (0.44 log units) below, and the stated range ends below it.
By their numbers in this assay, from the lowest: compounds 2 and 1 (each within the scatter of the next); then compound 3.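

Replacing the chloro group with hydrogen in this assay gives a 3.7-fold higher number from compound 1 to compound 3 (0.57 log units; beyond the scatter) and this step lies beyond the scatter. It is the first single change that can be read among these compounds, and it shows that this aromatic carbon, ortho to a large group, is not indifferent to what it carries: a real loss of inhibition follows when chloro leaves, with compound 3 at 2460 nM and the rest of compound 1 unchanged. No measurement here accounts for the size of this step.

As far as these compounds go, what remains open is whether chloro itself is needed on this carbon, or whether another group there, such as fluoro, bromo, methyl or an amine, would hold the number of compound 1 or lower it further. Also open, from the compounds shown here alone, is how the phenyl ring responds to a group placed elsewhere on it, and how much the ring of the shared core contributes, since compound 2 differs from compound 1 in more than one place and has no single-change partner.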